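A few compounds are considered here, and "the series" means these few. Any claim that something is new, unique, unknown or untested is made for them only; others in the source may bear on it.

Measured in a functional assay on HT-29 cells (Homo sapiens) for inhibition, read by luminescence and CellTiter-Glo, with a stated time of 24 h; on this read-out higher numbers stand for an effect only at larger amounts of compound and lower numbers for an effect already at smaller amounts:
- compound 1 `CC(C)CCn1nc(C(=O)N[C@H]2COc3ccccc3N(C)C2=S)nc1Cc1ccccc1`: 3640 nM
- compound 2 `CN1C(=S)[C@@H](NC(=O)c2nc(Cc3ccccc3)n(CCCF)n2)COc2ccccc21`: 4760 nM
- compound 3 `CN1C(=S)[C@@H](NC(=O)c2nc(Cc3ccccc3)n(CCCC(F)(F)F)n2)COc2ccccc21`: 2380 nM

Compound 3, at 2380 nM, cannot be separated from the other two compounds. The steps reaching it are a 1.5-fold lower number from compound 1 to compound 3 (0.18 log units; within the scatter) and a 2.0-fold lower number from compound 2 to compound 3 (0.30 log units; within the scatter).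

Compound 4 `CN1C(=S)[C@@H](NC(=O)c2nc(Cc3ccccc3)n(C3CCCC3)n2)COc2ccccc21` puts cyclopentyl in place of 4,4,4-trifluorobutyl on an aromatic nitrogen.

The nearest evidence comes from the chain changes on that aromatic nitrogen. Besides the two steps above, there is a 1.3-fold higher number from compound 1 to compound 2 (0.12 log units; within the scatter). None of the three leaves the scatter in this assay, so a step beyond the scatter is not expected, and no direction can be called. Within the data shown here, no measured compound carries a ring at this place, however, so the change goes beyond what the series has tested, and the range is kept wide.

The expected step is a 1.4-fold higher number from compound 3 to compound 4 (0.14 log units; within the scatter). For compound 4 the estimated value is 3300 nM, with an expected range of 1300 nM to 8000 nM.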

Compound 4, half-maximal effective concentration: 3530 nM
The estimate for compound 4 lay 1.1-fold (0.03 log units) below the measured number, within the range that was stated.
By their numbers in this assay, from the lowest: compounds 3, 4, 1 and 2 (each within the scatter of the next).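

In this assay, cyclopentyl on the aromatic nitrogen gives no step beyond the scatter against any of the open chains: a 1.5-fold higher number from compound 3 to compound 4 (0.17 log units; within the scatter), a 1.3-fold lower number from compound 2 to compound 4 (0.13 log units; within the scatter) and a 1.0-fold lower number from compound 1 to compound 4 (0.01 log units; within the scatter). The earlier compounds had shown this only for open chains; with compound 4, a five-membered non-aromatic ring of carbon only also falls within the scatter, so neither the ring nor the loss of fluorine separates compound 4 from compounds 1, 2 and 3. No measurement at hand explains why these four values stay so close together.

On these data alone, whether any group at this aromatic nitrogen can move the number beyond the scatter remains open, for instance a chain ending in an amine or a carboxylic acid. A six-membered ring such as cyclohexyl or phenyl in this place is equally untested among the compounds shown.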